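Adding a prenyl arm to two related polyprenylated cores

This account rests on a few compounds, and the source may have more. Where it says the series, first, only, none or still open, it means among the compounds named here.

Measured compounds:
compound 1 `CC(C)=CCC/C(C)=C/C[C@]12C[C@@H](CC=C(C)C)C(C)(C)[C@](CC=C(C)C)(C(=O)C(C(=O)c3ccc(O)c(O)c3)=C1O)C2=O`: 5.48 ug/mL
compound 2 `CC(C)=CCC/C(C)=C/C[C@]12C[C@@H](CC=C(C)C)C(C)(C)[C@](CC=C(C)C)(C(=O)CC1=O)C2=O`: 5.6 ug/mL
compound 3 `CC(C)=CCC/C(C)=C/C[C@]12C[C@@H](CC=C(C)C)C(C)(C)[C@](C/C=C(\C)CCC=C(C)C)(C(=O)C(C(=O)c3ccc(O)c(O)c3)=C1O)C2=O`: > 20 ug/mL

The series was tested in a functional assay on SGC-7901 cells (Homo sapiens) for inhibition; on this read-out higher numbers stand for weaker inhibition and lower numbers for stronger inhibition. Compound 1 gives 5.48 ug/mL. Compound 2 gives 5.6 ug/mL, a number within the scatter of that of compound 1, so the two are not separated by this assay. How the cores of compound 1 and compound 2 differ is not broken down here.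

Compound 3 carries the change 3-methylbut-2-en-1-yl in place of hydrogen on a saturated chain carbon bound to a double-bonded chain carbon on the core of compound 1. In this assay compound 3 reaches only a limit, > 20 ug/mL. The step of an at least 3.6-fold higher number from compound 1 to compound 3 (0.56 log units; beyond the scatter) is therefore known only as a lower bound because of the limit of > 20 ug/mL in this assay, at which 1 of the 3 values shown sits.

Compound 4 `CC(C)=CCC/C(C)=C/C[C@]12C[C@@H](CC=C(C)C)C(C)(C)[C@](C/C=C(\C)CCC=C(C)C)(C(=O)CC1=O)C2=O` is the unmeasured partner of compound 2: it carries the change (3-methylbut-2-en-1-yl in place of hydrogen on a saturated chain carbon bound to a double-bonded chain carbon), the same change at the same kind of place as from compound 1 to compound 3. Since compound 2 sits where compound 1 sits in this assay, the same change is expected to weaken inhibition by a similar amount, and a step of a 3.9-fold higher number from compound 2 to compound 4 (0.59 log units; beyond the scatter) is expected. Compound 4 is therefore estimated at 22 ug/mL in this assay, with a plausible range from 10 ug/mL to 60 ug/mL, and it is quite likely that only a limit would be reported, as for compound 3.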

Compound 4, half-maximal inhibitory concentration: > 20 ug/mL
Compound 4 gave a limit, no number; the forecaster's own chance of this, stated with the estimate: 60%; the middle value is on the limit's open side.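

In this assay compound 4 reaches only a limit, > 20 ug/mL, and not a number. The change of 3-methylbut-2-en-1-yl in place of hydrogen on a saturated chain carbon bound to a double-bonded chain carbon thus gives an at least 3.5-fold higher number from compound 2 to compound 4 (0.55 log units; beyond the scatter), so on both cores shown the longer arm goes with weaker inhibition, and neither pair goes against this. The direction of the change carries from the core of compound 1 to the core of compound 2, but the data do not show that its size carries too: the same change on two cores in this assay, an at least 3.6-fold higher number (0.56 log units; beyond the scatter) from compound 1 to compound 3 and an at least 3.5-fold higher number (0.55 log units; beyond the scatter) from compound 2 to compound 4; the limit leaves it open whether they differ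

The compounds shown leave open how much further inhibition would weaken on either core, and whether the same direction would hold on any core beyond these two. They also leave open what a shorter group such as a methyl or an ethyl, or a chain carrying a hydroxyl, an amine or a carboxylic acid, would do at that place in place of 3-methylbut-2-en-1-yl or 3,7-dimethylocta-2,6-dien-1-yl.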